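Chloro in Place of Hydrogen on the Phenyl of Compound 1

This account rests on a few compounds, and the source may have more. Where it says the series, first, only, none or still open, it means among the compounds named here.

Compound 1 `O=c1[nH]nc2n(c1=O)CCN2c1ccccc1` is one of two measured compounds in an ADME assay on Vero cells (Chlorocebus sabaeus) for cytotoxicity, with a stated time of 72 h, tested at 50 ug/mL (a lower number here means a weaker effect, a higher number a stronger effect of the compound at the concentration tested), where compound 1 gives 30%. This is the highest of the two numbers; the nearest is compound 2 `Cc1ccccc1N1CCn2c1n[nH]c(=O)c2=O`, which in this assay gives 0%. Among the compounds with values here, the one measured step joins these two, a number 30 percentage points lower from compound 1 to compound 2 (beyond the scatter), and its change is methyl in place of hydrogen on an aromatic carbon.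

Compound 3 `O=c1[nH]nc2n(c1=O)CCN2c1cccc(Cl)c1` is not yet measured in this assay. It differs from compound 1 in one place: chloro in place of hydrogen on an aromatic carbon. Within the data shown here, no measured step involves chloro, so the only guide is the methyl step, which lowered the read-out beyond the scatter when a substituent entered the phenyl ring. On that basis a downward step is expected in this assay, though with a different group entering the change may be smaller or fall within the scatter. The expected step is a number 15 percentage points lower from compound 1 to compound 3 (beyond the scatter). Compound 3 is therefore estimated to give 15%, within a range of 0% to 40%.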

Compound 3, a percentage reported as inhibition, at one concentration (the size of the read-out at that concentration, not a potency): 24%
Beside the measured number, compound 3's estimate is 9 percentage points below it; measured number inside the range.
By their numbers in this assay, from the lowest: compound 2; then compounds 3 and 1 (each within the scatter of the next).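

In this assay, chloro entering on an aromatic carbon of a six-membered aromatic ring of carbon only, meta to a large group, gives a number 6 percentage points lower from compound 1 to compound 3 (within the scatter) and so leaves no change that can be told from the scatter. The only earlier step, with methyl in place of hydrogen on an aromatic carbon, was a number 30 percentage points lower from compound 1 to compound 2 (beyond the scatter) and lay beyond the scatter, so a group entering this ring does not by itself bring a step of that kind: of the two steps shown, one lies beyond the scatter and one within it. Nothing shown bears on why the two steps differ.

The compounds shown leave open whether that difference follows the group that enters, the carbon it enters, or both, since chloro and methyl are each seen in one compound only. They also leave open how the read-out would respond to an amine, a carboxylic acid or a longer chain meta to a large group, and whether any such group would bring a step beyond the scatter.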